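The source may report more compounds than this note shows. Statements on the series, on what has been measured and on what is new or still open speak of the compounds shown alone.

Of the compounds shown here, three of one shared core have been measured in a functional assay, with a stated time of 20 min; a higher number here means a weaker inhibitor, a lower number a stronger inhibitor. Compound 1 `COc1ccc(-c2nc(NN)n(C)c(=O)c2C#N)cc1` gives 41 ug/mL in this assay. Compound 2 `CCOC(=O)c1cnn(-c2nc(-c3ccccc3F)c(C#N)c(=O)n2C)c1N` gives 69 ug/mL. Compound 3 `CSc1nc(-c2ccco2)c(C#N)c(=O)n1C` gives 68 ug/mL. On these numbers compound 2 is the point of departure; its gap to compound 3 and its gap to compound 1 both fall within the usual scatter of repeated measurements, so the three cannot be told apart on what has been seen.

The compound that has not yet been measured is compound 4 `CCOC(=O)c1cnn(-c2nc(-c3ccco3)c(C#N)c(=O)n2C)c1N`. It differs from compound 2 in one place: furan-2-yl in place of 2-fluorophenyl on an aromatic carbon. Among the measured compounds shown here, nothing among the measured compounds isolates this change, since compound 3 carries the furan-2-yl but differs from compound 2 elsewhere as well; what can be said is only that compound 3 and compound 2 sit within the scatter of one another in this assay.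

For the measured compounds named here, with no isolated step to lean on, the expectation for compound 4 is a step of a 1.1-fold lower number from compound 2 to compound 4 (0.03 log units; within the scatter), that is, none beyond the scatter in either direction. Compound 4 is therefore estimated at 65 ug/mL in this assay, with a likely range from 30 ug/mL to 140 ug/mL.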

Compound 4, half-maximal inhibitory concentration: 91 ug/mL
Compound 4: the middle estimate sits 1.4-fold (0.15 log units) below what was measured; measured number inside the range.
By their numbers in this assay, from the lowest: compounds 1, 3, 2 and 4 (each within the scatter of the next, the first and the last beyond it).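

In this assay, the exchange of 2-fluorophenyl for furan-2-yl on the aromatic carbon ortho to a cyano group is now seen alone, as a 1.3-fold higher number from compound 2 to compound 4 (0.12 log units; within the scatter) and with the rest of compound 2 held fixed. The earlier compounds shown here could not show this, since compound 3 carries the furan-2-yl but differs from compound 2 elsewhere as well. At this position, then, a six-membered aromatic ring of carbon only and a five-membered aromatic ring with 1 hetero atom cannot be told apart in this read-out, and no outside evidence bears on the result.

Going by these compounds, both groups compared here are aromatic rings, so it remains open whether an unsubstituted phenyl, which would separate the fluorine from the ring that bears it, or a non-aromatic group such as an amine, a carboxylic acid or a longer alkyl chain would give a step beyond the scatter at this carbon. On these data alone, it also remains open whether the same exchange would stay within the scatter on compounds that differ from compound 2 elsewhere on the shared core.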